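Replacing the Benzoyl Amide with an Acetyl Amide

This account rests on a few compounds, and the source may have more. Where it says the series, first, only, none or still open, it means among the compounds named here.

Measured compounds:
Compound 1, `O=C(CSc1nc2ccc(NC(=O)c3ccccc3)cc2s1)NCc1ccc(Cl)cc1`: 30100 nM
Compound 2, `CNC(=O)CSc1nc2ccc(NC(=O)c3ccccc3)cc2s1`: 26500 nM
Compound 3, `COc1ccc(CNC(=O)CSc2nc3ccc(NC(=O)c4ccccc4)cc3s2)cc1`: 12700 nM

All three were tested in a functional assay on HepG2 cells (Homo sapiens) for cytotoxicity, read by MTT assay, with a stated time of 48 h; on this read-out higher numbers stand for weaker inhibition and lower numbers for stronger inhibition. Compound 2 gives the second highest of the three numbers, close to compound 1 (the step of a 1.1-fold lower number from compound 1 to compound 2 (0.06 log units; within the scatter) is within the scatter) and further from compound 3, as shown by a 2.1-fold lower number from compound 2 to compound 3 (0.32 log units; beyond the scatter). Compound 4, `CNC(=O)CSc1nc2ccc(NC(C)=O)cc2s1`, differs from compound 2 at the other end of the shared core: methyl in place of phenyl on a carbonyl carbon. Within the data shown here, none of the measured steps touches this amide; all three alter the chain carbon bound to the other amide nitrogen or its ring. There is thus no direct guide, and no step beyond the scatter is expected for compound 4: a 1.1-fold higher number from compound 2 to compound 4 (0.05 log units; within the scatter). Compound 4 is estimated at 30000 nM, with a range from 12000 nM to 80000 nM.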

Compound 4, half-maximal inhibitory concentration: > 100000 nM
Compound 4: a limit, no number; the forecaster's own chance of this, stated with the estimate: 10%; middle value at least 3.3-fold (0.52 log units) away from the limit.
By their numbers in this assay, from the lowest: compound 3; then compounds 2 and 1 (each within the scatter of the next). At a limit, above all of these: compound 4.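

In this assay, among these compounds, the change from benzoyl to acetyl gives an at least 3.7-fold higher number from compound 2 to compound 4 (0.57 log units; beyond the scatter) and is the first step at this end of the shared core. For compound 4 the reading is a limit, not a number: the limit of > 100000 nM in this assay, at which 1 of the 4 values shown sits. Replacing phenyl with methyl on this carbonyl carbon therefore weakens inhibition, by an amount the limit leaves unknown.

Still open, as far as these compounds go, is how an ethyl chain, a cyclohexyl ring or a pyridine ring would behave on this carbonyl carbon. Also open, from the compounds shown here alone, is whether benzoyl to acetyl has the same outcome alongside the 4-methoxyphenyl of compound 3.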